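The source may hold more compounds than are shown below. What is called first, only, known or untested is meant among the compounds shown, and "the series" means these compounds.

Compound 1 `Nc1ncn(CCC2(N)OC(=O)C(OCc3ccccc3)=C2OCc2ccccc2)c(=O)n1` is the saturated member of this small set, with an amino group on the ring carbon and an aminotriazinone on the chain. In a functional assay on MIA PaCa-2 cells (Homo sapiens) for inhibition, read by MTT assay, with a stated time of 72 h (on this read-out lower numbers stand for stronger inhibition and higher numbers for weaker inhibition), compound 1 gives only a limit, > 100000 nM, so its place among the measured numbers cannot be fixed more closely than the limit of > 100000 nM in this assay, at which 1 of the 3 values shown sits. The two companions carry the unsaturated core: compound 2 `O=C1O/C(=C\Cn2ncc(=O)[nH]c2=O)C(OCc2ccccc2)=C1OCc1ccccc1` gives 20400 nM in this assay, and compound 3 `O=C1O/C(=C\Cn2c(=O)[nH]c(=O)[nH]c2=O)C(OCc2ccccc2)=C1OCc1ccccc1` gives 37900 nM.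

Compound 4 `NC1(CCn2c(=O)[nH]c(=O)[nH]c2=O)OC(=O)C(OCc2ccccc2)=C1OCc1ccccc1` differs from compound 1 by a group of 9 heavy atoms (3 carbon, 3 nitrogen, 3 oxygen; one six-membered aromatic ring with 3 hetero atoms) in place of a group of 8 heavy atoms (3 carbon, 4 nitrogen, 1 oxygen; one six-membered aromatic ring with 3 hetero atoms), on a saturated chain carbon, two bonds along the chain from a saturated ring carbon; at that saturated chain carbon, two bonds along the chain from a saturated ring carbon, the entering six-membered aromatic ring with 3 hetero atoms brings 2 hydrogen-bond donors and 4 hydrogen-bond acceptors where the leaving ring had 1 hydrogen-bond donor and 5 hydrogen-bond acceptors.

Within the data shown here, the one measured step that bears on this exchange of one such ring for another on the chain is a 1.9-fold higher number from compound 2 to compound 3 (0.27 log units; within the scatter). No shift beyond the scatter is therefore expected in this assay from compound 1 to compound 4. Since compound 1 already sits at a limit, compound 4 is expected to remain there as well, with an estimate of 150000 nM spanning 50000 nM to 500000 nM, corresponding to a step that the limit leaves unreadable from compound 1 to compound 4.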

Compound 4, half-maximal inhibitory concentration: > 100000 nM
Compound 4 ended at the assay's limit; the forecaster's own chance of this, stated with the estimate: 70%; the middle value lies beyond the limit too.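

Compound 4 gives > 100000 nM in this assay, which is a limit of the assay and not a number. Among these compounds, compound 1 and compound 4 thus share one limit, and no step between them can be read: the limit of > 100000 nM in this assay, at which 2 of the 4 values shown sit. The compounds shown leave open whether exchanging one ring for the other changes the read-out at all on the core of compound 1.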